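The source may hold more compounds than are shown below. What is called first, only, known or untested is meant among the compounds shown, and "the series" means these compounds.

Working notes on the ester and aryl chloride pair in the series.

Compound 2 `CCOC(=O)c1cc2cc(/C=C/C(=O)c3ccccc3)cc(C(C)CC)c2oc1=O` carries an ethyl ester; in a functional assay on C-33-A cells (Homo sapiens) for cytotoxicity, read by sulforhodamine B assay, with a stated time of 48 h (on this read-out lower numbers stand for stronger inhibition and higher numbers for weaker inhibition), compound 2 gives 8120 nM. Compound 1 `CCC(C)c1cc(/C=C/C(=O)c2ccccc2)cc2cc(C(=O)OC)c(=O)oc12` differs from it by hydrogen in place of methyl on a saturated chain carbon bound to an oxygen next to a carbonyl group, and in this assay compound 1 gives 6280 nM, a step of a 1.3-fold lower number from compound 2 to compound 1 (0.11 log units; within the scatter). Compound 3 `CCOC(=O)c1cc2cc(/C=C/C(=O)c3ccc(Cl)cc3)cc(C(C)CC)c2oc1=O` differs from compound 2 by chloro in place of hydrogen on an aromatic carbon, and in this assay compound 3 gives 4540 nM, a step of a 1.8-fold lower number from compound 2 to compound 3 (0.25 log units; within the scatter). All three values sit close together, and none of the steps among them is large enough to set an order.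

Compound 4 `CCC(C)c1cc(/C=C/C(=O)c2ccc(Cl)cc2)cc2cc(C(=O)OC)c(=O)oc12` is not yet measured in this assay. It differs from compound 3 by hydrogen in place of methyl on a saturated chain carbon bound to an oxygen next to a carbonyl group, which is the same change as that from compound 2 to compound 1, made here on the core that already carries the chloro group; the two cores differ by chloro in place of hydrogen on an aromatic carbon. The change occurs twice among these compounds, and the one measured instance of it gave a 1.3-fold lower number from compound 2 to compound 1 (0.11 log units; within the scatter).

For the measured compounds named here, the step from compound 3 to compound 4 in this assay is expected to be about as small, roughly a 1.3-fold lower number from compound 3 to compound 4 (0.11 log units; within the scatter), because the only precedent is a 1.3-fold lower number from compound 2 to compound 1 (0.11 log units; within the scatter) and nothing in the data suggests the chloro group alters it. On that basis compound 4 is estimated at 3500 nM in this assay, with a likely range from 1700 nM to 7200 nM.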

Compound 4, half-maximal inhibitory concentration: 5900 nM
Compound 4: middle estimate off by 1.7-fold (0.23 log units), on the low side, and the stated range covers the measured number.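

On the core of compound 3, the change from ethoxycarbonyl to methoxycarbonyl gives a 1.3-fold higher number from compound 3 to compound 4 (0.11 log units; within the scatter) in this assay, and it does not differ from the same change on the core of compound 2: the same change on two cores in this assay, a 1.3-fold lower number (0.11 log units; within the scatter) from compound 2 to compound 1 and a 1.3-fold higher number (0.11 log units; within the scatter) from compound 3 to compound 4, 1.7-fold (0.23 log units) apart, within the scatter of two such steps. The chloro change on the core of compound 1 gives a 1.1-fold lower number from compound 1 to compound 4 (0.03 log units; within the scatter), and it likewise does not differ from its counterpart on the core of compound 2: the same change on two cores in this assay, a 1.8-fold lower number (0.25 log units; within the scatter) from compound 2 to compound 3 and a 1.1-fold lower number (0.03 log units; within the scatter) from compound 1 to compound 4, 1.7-fold (0.23 log units) apart, within the scatter of two such steps. Both changes therefore carry between these cores without a detectable difference, but since all four steps lie within the scatter, this shows only that they stay small here, not that either change has a real direction or that the two add up, and two cores cannot establish a rule for the series.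

On these data alone, what remains open is whether a larger change at the ester, such as a carboxylic acid, an amide or a longer chain, would move the number beyond the scatter, and whether an amine or a methoxy group on the aromatic carbon that carries the chloro would do so. Also open is whether these small steps would hold on cores other than the ones shown here.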